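A Dichlorophenyl Swap Against an Inactive Baseline

This account rests on a few compounds, and the source may have more. Where it says the series, first, only, none or still open, it means among the compounds named here.

Of the compounds shown here, three built on a shared core have been tested in a functional assay on SEM cells (Homo sapiens) for cytotoxicity, with a stated time of 72 h; on this read-out lower numbers stand for an effect already at smaller amounts and higher numbers for an effect only at larger amounts of compound. Compound 1 `C=C[C@@](C)(/C=C/c1ccc(O)cc1)CC/C=C(C)/C=N/N` reached only the limit of the assay, giving > 36600 nM. Compound 2 `C=C[C@@](C)(/C=C/c1ccc(Nc2ccc(OC)c(OC)c2)cc1)CCC=C(C)C` also stopped at a limit, with > 36600 nM. Compound 3 `C=C[C@@](C)(/C=C/c1ccc(Nc2ccc(OC)c(F)c2)cc1)CCC=C(C)C` likewise shows only a limit, > 36600 nM. For the measured compounds named here, the one step between measured neighbours, a step that the two limits leave unreadable from compound 2 to compound 3, cannot be sized because of the limit of > 36600 nM in this assay, at which 3 of the 3 values shown sit. So compound 3 stands where every measured compound stands: at the limit, with no number to rank it against the others.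

Compound 4 `C=C[C@@](C)(/C=C/c1ccc(Nc2ccc(Cl)c(Cl)c2)cc1)CCC=C(C)C` differs from compound 3 by a single change: 3,4-dichlorophenyl in place of 3-fluoro-4-methoxyphenyl on a nitrogen on an aromatic ring. Going by the values given here, no measured step bears on this change, and the only step that is known is itself unreadable, so neither a size nor a direction can be drawn from the data. What the three limits do show is that the series has not yet produced a readable number in this assay, and compound 4 is expected to remain at or near that limit. The estimate for compound 4 is 50000 nM, with a range from 15000 nM to 200000 nM. The step this estimate means, a step that the limit leaves unreadable from compound 3 to compound 4, is expected to be none beyond the scatter.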

Compound 4, half-maximal effective concentration: > 36600 nM
Compound 4: only a limit was reported; the forecaster's own chance of this, stated with the estimate: 75%; the middle value is on the limit's open side.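

Compound 3 and compound 4 both stop at a limit, so the step between them cannot be read, and no size or direction can be given because of this: the limit of > 36600 nM in this assay, at which 4 of the 4 values shown sit.

The compounds shown leave open which change to the shared core, if any, would give a readable number in this assay at all.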